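Diethylamino for hydroxy on the hydroxymethyl arm of compound 1

This account rests on a few compounds, and the source may have more. Where it says the series, first, only, none or still open, it means among the compounds named here.

Measured so far:
compound 1 `CCNC(=O)c1noc(-c2cc(C(C)C)c(O)cc2O)c1-c1cc(CO)no1`: 13 nM
compound 2 `CCNC(=O)c1noc(-c2cc(C(C)C)c(O)cc2O)c1-c1cc(COCC(=O)O)no1`: "not determined" (no result reported)

Among the compounds with values here, in a functional assay on HCT-116 cells (Homo sapiens) for inhibition (on this read-out lower numbers stand for stronger inhibition and higher numbers for weaker inhibition), compound 1 gives 13 nM, the only number so far. For compound 2 the read-out stands as "not determined" (no result reported), so no comparison is possible.

Compound 3 `CCNC(=O)c1noc(-c2cc(C(C)C)c(O)cc2O)c1-c1cc(CN(CC)CC)no1` differs from compound 1 in one place: diethylamino in place of hydroxy on a saturated chain carbon bound to an aromatic carbon. Within the data shown here, no step between measured compounds exists to calibrate this change. The change is expected to move this assay little, within the scatter, giving an expected step of a 1.2-fold higher number from compound 1 to compound 3 (0.06 log units; within the scatter).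

For compound 3 the estimate in this assay is 15 nM, expected between 5 nM and 50 nM.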

Compound 3, half-maximal inhibitory concentration: 38 nM
Estimate against measurement, compound 3: 2.5-fold (0.40 log units) below; measured number inside the range.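

In this assay this position accepts diethylamino in place of hydroxy with a measurable cost: the change gives a 2.9-fold higher number from compound 1 to compound 3 (0.47 log units; beyond the scatter) and the step is modest, beyond the scatter. Inhibition is weakened but not lost, as compound 3 still reads 38 nM in this assay and the hydroxy is therefore not essential here. Nothing shown accounts for the size of this step.

One step cannot separate the loss of the hydroxy from the entry of the diethylamino. On these data alone, how a methoxy, a primary amine or a morpholine on this arm would read stays open.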